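One Chain Shortened: What Compound 3 May Show

The source may report more compounds than this note shows. Statements on the series, on what has been measured and on what is new or still open speak of the compounds shown alone.

Compound 1 `O=c1oc2ccccc2n1CCCCCN1CCN(CCCCCn2c(=O)oc3ccccc32)CC1`: 19400 nM
Compound 2 `O=c1sc2ccccc2n1CCCCCN1CCN(CCn2c(=O)sc3ccccc32)CC1`: 23800 nM

In an ADME assay on Vero cells (Chlorocebus sabaeus) for cytotoxicity, read by neutral red uptake, with a stated time of 48 h (a higher number here means a weaker inhibitor, a lower number a stronger inhibitor), compound 1 gives 19400 nM, and compound 2 lies within the scatter of it. Compound 3 `O=c1oc2ccccc2n1CCCCCN1CCN(CCCCn2c(=O)oc3ccccc32)CC1` departs from compound 1 in one place: a group of 10 heavy atoms (7 carbon, 1 nitrogen, 2 oxygen; one five-membered aromatic ring with 2 hetero atoms, one six-membered aromatic ring of carbon only) in place of a group of 11 heavy atoms (8 carbon, 1 nitrogen, 2 oxygen; one five-membered aromatic ring with 2 hetero atoms, one six-membered aromatic ring of carbon only), on a saturated chain carbon, four bonds along the chain from an amine nitrogen in a ring. Among the compounds with values here, no step between measured compounds shows this change. A step within the scatter is expected in this assay, since compound 2 at 23800 nM stays close to compound 1 at 19400 nM. The estimated step is a 1.1-fold higher number from compound 1 to compound 3 (0.03 log units; within the scatter). For compound 3 the estimated value is 21000 nM, with an expected range of 10000 nM to 42000 nM.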

Compound 3, half-maximal inhibitory concentration: 17600 nM
The estimate for compound 3 lay 1.2-fold (0.08 log units) above the measured number; the range from low to high includes it.
By their numbers in this assay, from the lowest: compounds 3, 1 and 2 (each within the scatter of the next).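

In this assay, the group of 10 heavy atoms in place of the group of 11 heavy atoms, on a saturated chain carbon, four bonds along the chain from an amine nitrogen in a ring, gives a 1.1-fold lower number from compound 1 to compound 3 (0.04 log units; within the scatter) as the first step read at this position. Compound 1 and compound 3 thus remain within the scatter of each other. Nothing measured here explains this result. The compounds shown leave open whether a longer chain at this position, or a carboxylic acid on it, would give a number within the scatter of compound 1.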